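A Fluoro for Methyl Swap on a Shared Core

The source may hold more compounds than are shown below. What is called first, only, known or untested is meant among the compounds shown, and "the series" means these compounds.

Of the compounds shown here, three sharing one core have been tested in an ADME assay on MT4 cells (Homo sapiens) for cytotoxicity; on this read-out higher numbers stand for lower toxicity in this test and lower numbers for higher toxicity in this test. Compound 1 `C=C(C)CNC(=S)Nc1cccc(C(F)(F)F)c1` gives 43000 nM, and compound 2 `CCCCc1ccc(NC(=S)Nc2cccc(C(F)(F)F)c2)c(C)c1` gives 43000 nM in this assay. Compound 3 `Cc1ccc(NC(=S)Nc2cccc(C(F)(F)F)c2)cc1Cl` gives 20000 nM in this assay, the lowest of the three numbers; both other compounds sit higher by a gap beyond the usual scatter, so compound 3 shows the highest toxicity of the three in this test.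

Compound 4 `Fc1ccc(NC(=S)Nc2cccc(C(F)(F)F)c2)cc1Cl` has not yet been measured. It differs from compound 3 by a single change: fluoro in place of methyl on an aromatic carbon. Going by the values given here, no pair of measured compounds shows a change of this kind, so the data give no direction for the number to move. The replacement is a small one, as the counted difference shows. The step expected in this assay is a 1.3-fold higher number from compound 3 to compound 4 (0.10 log units; within the scatter), a shift no larger than the usual scatter in either direction. The estimate for compound 4 in this assay is 25000 nM, with a likely range from 10000 nM to 60000 nM.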

Compound 4, half-maximal cytotoxic concentration: 8000 nM
For compound 4 the middle estimate is 3.1-fold (0.49 log units) above the measured one, and the stated range ends above it.
By their numbers in this assay, from the lowest: compound 4; then compound 3; then compounds 1 and 2 (each within the scatter of the next).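

In this assay fluoro in place of methyl on this aromatic carbon, ortho to a chloro group and para to a large group, gives a 2.5-fold lower number from compound 3 to compound 4 (0.40 log units; beyond the scatter) and so supplies the first direction for this change, towards higher toxicity in this test. The position therefore responds to the exchange of one heavy atom for another, even though the counted differences between the two groups are small. Nothing available explains why the number moves.

From the compounds shown here alone, this direction rests on a single pair of compounds, so it remains unknown whether the same swap would act alike on the other compounds sharing this core. Also open, going by these compounds, is how the number would respond to a different group on this carbon, such as a methoxy group, an amine or a longer chain.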